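The source may report more compounds than this note shows. Statements on the series, on what has been measured and on what is new or still open speak of the compounds shown alone.

Measured so far:
compound 1, `CS(=O)(=O)c1ccc(-c2nc3ccccn3c2Sc2ccccc2)cc1`, 67800 nM
compound 2, `C(=C/c1nc2ccccn2c1Sc1ccccc1)\c1ccccc1`, 22000 nM
compound 3, `Cc1ccc2nc(-c3ccc(Cl)cc3)c(Sc3ccccc3)n2c1`, 95100 nM

In a functional assay on DU-145 cells (Homo sapiens) for inhibition, read by MTT assay, with a stated time of 48 h (a lower number here means a stronger inhibitor, a higher number a weaker inhibitor), compound 1 stands second highest of the three numbers. Its nearest neighbour is compound 3, whose value lies within the scatter of that of compound 1, so no order can be read between them. Compound 2 gives the lowest number, and its gap to compound 1 lies beyond the scatter.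

The step from compound 1 to compound 4, `Clc1ccc(-c2nc3ccccn3c2Sc2ccccc2)cc1`, is a single change: chloro in place of methylsulfonyl on an aromatic carbon. Going by the values given here, no measured pair shows this change, so there is no step to lean on. With the measured numbers all clustered at the weak end of this assay, compound 4 is expected to give 80000 nM, between 30000 nM and 200000 nM. The estimated step of a 1.2-fold higher number from compound 1 to compound 4 (0.07 log units; within the scatter) is expected to stay within the scatter.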

Compound 4, half-maximal inhibitory concentration: 30700 nM
For compound 4 the middle estimate is 2.6-fold (0.42 log units) above the measured one; the range from low to high includes it.
By their numbers in this assay, from the lowest: compounds 2 and 4 (each within the scatter of the next); then compounds 1 and 3 (each within the scatter of the next).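

In this assay, chloro in place of methylsulfonyl on an aromatic carbon, para to a large group, gives a 2.2-fold lower number from compound 1 to compound 4 (0.34 log units; beyond the scatter), so the number at this position responds to this change, though modestly. Hydrogen in place of methyl on an aromatic carbon gives a 3.1-fold lower number from compound 3 to compound 4 (0.49 log units; beyond the scatter), showing a second place that responds, whereas 4-chlorophenyl in place of 2-phenylethenyl gives a 1.4-fold higher number from compound 2 to compound 4 (0.14 log units; within the scatter), which allows no order to be read. Nothing available explains these steps.

The compounds shown leave open how an amine or a carboxylic acid would fare at the position that carries chloro in compound 4.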